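The source may hold more compounds than are shown below. What is called first, only, known or untested is meant among the compounds shown, and "the series" means these compounds.

Of the compounds shown here, three of a shared core have been measured in a functional assay on the whole organism with Rattus norvegicus as the target; on this read-out higher numbers stand for an effect only at larger amounts of compound and lower numbers for an effect already at smaller amounts. Compound 1 `CCc1c(SC)nc2nc(C(=O)c3ccccc3)cn2c1C` gives 2 mg/kg, compound 2 `COc1nc2nc(C(=O)c3ccccc3)cn2c(C)c1CC1CC1` gives 10 mg/kg, and compound 3 `CCCCc1c(OC)nc2nc(C(=O)c3ccccc3)cn2c1C` gives 2 mg/kg. Compound 3 is level with compound 1 at the digits shown, and the two together carry the lowest numbers of the three; compound 2 stands furthest from compound 3, as the step of a 5.0-fold lower number from compound 2 to compound 3 (0.70 log units; beyond the scatter) shows. Compound 4 `CCc1c(OC)nc2nc(C(=O)c3ccccc3)cn2c1C` differs from compound 3 in one place: hydrogen in place of ethyl on a saturated chain carbon, two bonds along the chain from an aromatic carbon. For the measured compounds named here, no measured step shortens this chain in the same way, so the only step touching the same region is a 5.0-fold lower number from compound 2 to compound 3 (0.70 log units; beyond the scatter), which shows that reworking this chain can move this assay modestly. Compound 1 shares the ethyl chain of compound 4 while carrying a different group elsewhere, and its value sits level with compound 3. Compound 4 is therefore expected to stay close to compound 3, with the step of a 1.5-fold higher number from compound 3 to compound 4 (0.18 log units; within the scatter) estimated to lie within the scatter. The estimate for compound 4 is 3 mg/kg, expected between 1 mg/kg and 8 mg/kg.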

Compound 4, minimum effective dose: 2 mg/kg
Compound 4: middle estimate off by 1.5-fold (0.18 log units), on the high side; the measured number falls inside the stated range.
By their numbers in this assay, from the lowest: compounds 1, 3 and 4 (each within the scatter of the next); then compound 2.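

In this assay, cutting the butyl chain back to ethyl changes nothing that can be read (no change at the digits printed from compound 3 to compound 4 (within the scatter)), so the two outer carbons of the butyl chain are not needed to hold this number. The ethyl chain also stands as far from the cyclopropyl-bearing chain (a 5.0-fold lower number from compound 2 to compound 4 (0.70 log units; beyond the scatter)) as the butyl chain does (a 5.0-fold lower number from compound 2 to compound 3 (0.70 log units; beyond the scatter)), so among these compounds only the cyclopropyl-bearing chain goes with the higher number, whether the straight chain is long or short. With the ethyl chain held fixed, methoxy and methylsulfanyl on the aromatic carbon also show no difference (no change at the digits printed from compound 1 to compound 4 (within the scatter)).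

As far as these compounds go, whether a methyl group at this place, or a chain ending in an amine or a carboxylic acid, would keep the same number remains open. Nothing at hand explains why these numbers fall as they do.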